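A Methyl Step From Compound 1

The compounds below may be only part of what the source reports. "The series", "measured", "known", "first", "only" and "open" are said of these compounds alone.

Going by the values given here, in a functional assay on MOLT-4 cells (Homo sapiens) for inhibition (on this read-out higher numbers stand for weaker inhibition and lower numbers for stronger inhibition), compound 1 `O=C1CCCCC/C1=C\c1ccccc1` gives 215000 nM, the highest of the three numbers measured so far. Compound 2 `O=C1CCCCC/C1=C\c1ccc(Cl)cc1`, with chloro in place of hydrogen on an aromatic carbon, gives 52600 nM. Compound 3 `O=C1CCCCC/C1=C\c1ccc(Br)cc1`, with bromo in place of hydrogen on an aromatic carbon, gives 49400 nM. These changes show a 4.1-fold lower number from compound 1 to compound 2 (0.61 log units; beyond the scatter) and a 4.4-fold lower number from compound 1 to compound 3 (0.64 log units; beyond the scatter), both modest. Exchanging one halogen for the other shows a 1.1-fold lower number from compound 2 to compound 3 (0.03 log units; within the scatter), so the two cannot be told apart here.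

Compound 4 `Cc1cccc(/C=C2\CCCCCC2=O)c1` has not yet been measured. It differs from compound 1 by methyl in place of hydrogen on an aromatic carbon, which is methyl in place of hydrogen on an aromatic carbon. Among the compounds with values here, the two halogen steps from compound 1 are the only measured changes that bear on it, and they also replace hydrogen on an aromatic carbon. Within the data shown here, no measured compound carries a methyl, so this comparison is only a loose guide. A lower number is therefore expected, though by less than those two steps and perhaps not beyond the scatter. The expected change is a 1.8-fold lower number from compound 1 to compound 4 (0.25 log units; within the scatter). For compound 4 the estimated value is 120000 nM, with an expected range from 55000 nM to 250000 nM.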

Compound 4, half-maximal inhibitory concentration: 228000 nM
The estimate for compound 4 lay 1.9-fold (0.28 log units) below the measured number; the measured number falls inside the stated range.
By their numbers in this assay, from the lowest: compounds 3 and 2 (each within the scatter of the next); then compounds 1 and 4 (each within the scatter of the next).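

In this assay, methyl in place of hydrogen on an aromatic carbon, meta to a group of 9 heavy atoms, gives a 1.1-fold higher number from compound 1 to compound 4 (0.03 log units; within the scatter), so this substitution cannot be told apart from the unsubstituted compound. Adding a group to the aromatic ring therefore does not by itself bring a lower number: the chloro and bromo steps, a 4.1-fold lower number from compound 1 to compound 2 (0.61 log units; beyond the scatter) and a 4.4-fold lower number from compound 1 to compound 3 (0.64 log units; beyond the scatter), remain the only steps from compound 1 beyond the scatter, and they differ from the methyl step both in the group that enters and in the ring carbon that carries it. Nothing available here accounts for this result.

Among the compounds shown, it remains open whether the gap between the halogen steps and the methyl step follows the group or the ring carbon it occupies. Going by these compounds, it also remains open what a methoxy group, an amine or a carboxylic acid would give at the place the methyl holds in compound 4.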